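The compounds below may be only part of what the source reports. "The series", "measured", "known", "first", "only" and "open" are said of these compounds alone.

Measured compounds:
Compound 1, `COc1nn(Cc2ccccc2N)c(=O)o1`: 8%
Compound 2, `COc1nn(Cc2ccccc2NC(C)=O)c(=O)o1`: 11%

In an assay on COS-7 cells for inhibition of Fatty-acid amide hydrolase 1 (Homo sapiens), read by scintillation counting, with a stated time of 10 min, tested at 10 uM (on this read-out lower numbers stand for less inhibition and higher numbers for more inhibition at the one concentration tested (going by the name of the read-out)), compound 2 gives 11%, while compound 1 gives 8%. Both numbers are small, and the two lie within the scatter of each other, so compound 2 cannot be set apart from compound 1 on these data. Within the data shown here, the one measured step, a number 3 percentage points higher from compound 1 to compound 2 (within the scatter), replaced a hydrogen with an acetyl group on a nitrogen of the aromatic ring and left the read-out essentially unchanged.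

Compound 3, `COc1nn(Cc2ccccc2NC(=O)c2ccccc2)c(=O)o1`, carries the change (phenyl in place of methyl on a carbonyl carbon), so the acetyl group becomes a benzoyl group. Among the measured compounds shown here, the only step that bears on this, a number 3 percentage points higher from compound 1 to compound 2 (within the scatter), was within the scatter, and nothing measured here tells how a larger group on that carbonyl carbon behaves. The expected step in this assay is therefore a number 4 percentage points higher from compound 2 to compound 3 (within the scatter), none beyond the scatter. Compound 3 is estimated at 15%, with a range from 0% to 40%.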

Compound 3, a percentage reported as inhibition, at one concentration (the size of the read-out at that concentration, not a potency): "not active" (no number reported)
No number was reported for compound 3; no gap can be computed for the estimate.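

In this assay, among these compounds, compound 3 is reported only as not active, without a number, and no step from compound 2 to compound 3 can be read. The compounds shown leave open how a benzoyl group compares with an acetyl group in size of inhibition. Nothing here offers an explanation for this result.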